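Hydroxy to methoxy: the step from compound 2 to compound 4

The source may report more compounds than this note shows. Statements on the series, on what has been measured and on what is new or still open speak of the compounds shown alone.

Measured in an assay on isolated protein for inhibition of Maltase-glucoamylase (Homo sapiens), with a stated time of 15 min; on this read-out higher numbers stand for weaker inhibition and lower numbers for stronger inhibition:
compound 1 `COc1ccc(O)c(/C=N/NC(=O)c2ccc(-c3nc4ccccc4s3)cc2)c1` gives 6500 nM
compound 2 `O=C(N/N=C/c1ccc(O)c(O)c1)c1ccc(-c2nc3ccccc3s2)cc1` gives 15100 nM
compound 3 `O=C(N/N=C/c1ccc(F)c(Br)c1)c1ccc(-c2nc3ccccc3s2)cc1` gives 28000 nM

Compound 2 stands second highest of the three numbers; to compound 3 the gap a 1.9-fold higher number from compound 2 to compound 3 (0.27 log units; within the scatter) lies within the scatter, while the step of a 2.3-fold higher number from compound 1 to compound 2 (0.37 log units; beyond the scatter) is beyond it. Compound 4 `COc1cc(/C=N/NC(=O)c2ccc(-c3nc4ccccc4s3)cc2)ccc1O` differs from compound 2 by methyl in place of hydrogen on an oxygen on an aromatic ring, giving 4-hydroxy-3-methoxyphenyl in place of 3,4-dihydroxyphenyl. For the measured compounds named here, no measured step tests this change directly; the nearest bearing is that compound 1, which carries one hydroxy and one methoxy, sits at the lower end, so a modest move downward at most is expected, likely within the scatter. For compound 4 the expected step in this assay is a 1.5-fold lower number from compound 2 to compound 4 (0.18 log units; within the scatter). Compound 4 is therefore estimated at 10000 nM, ranging from 5000 nM to 22000 nM.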

Compound 4, half-maximal inhibitory concentration: 53300 nM
Beside the measured number, compound 4's estimate is 5.3-fold (0.73 log units) below it, outside the stated range (above it).
By their numbers in this assay, from the lowest: compound 1; then compounds 2, 3 and 4 (each within the scatter of the next, the first and the last beyond it).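

Methyl on this oxygen is not a silent change in this assay: the step is a 3.5-fold higher number from compound 2 to compound 4 (0.55 log units; beyond the scatter), so the hydroxy of 3,4-dihydroxyphenyl cannot be capped freely. The result sits level with the 3-bromo-4-fluorophenyl group, at a 1.9-fold higher number from compound 3 to compound 4 (0.28 log units; within the scatter). Holding one hydroxy and one methoxy does not by itself set the number, since 2-hydroxy-5-methoxyphenyl changing to 4-hydroxy-3-methoxyphenyl gives an 8.2-fold higher number from compound 1 to compound 4 (0.91 log units; beyond the scatter).

No supporting data explain the loss. Still open, going by these compounds, is whether ethoxy, or an amine in place of the hydroxy, would follow methoxy on this ring.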